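A few compounds are considered here, and "the series" means these few. Any claim that something is new, unique, unknown or untested is made for them only; others in the source may bear on it.

Compound 3 `O=C(CCc1ccccc1)NC(=S)N1CCc2c(OCCCCCOc3ccc(Cl)cc3)cccc21` is one of three close relatives that share a core and differ only in the group attached to a carbonyl carbon. In an ADME assay on Huh-7 cells (Homo sapiens) for cytotoxicity (on this read-out lower numbers stand for higher toxicity in this test and higher numbers for lower toxicity in this test), compound 3 gives > 50000 nM, which is a limit of the assay and not a number. Compound 1 `O=C(NC(=S)N1CCc2c(OCCCCCOc3ccc(Cl)cc3)cccc21)Oc1ccccc1` carries a phenoxy group on that carbonyl carbon; in this assay compound 1 gives > 50000 nM, again a limit. Compound 2 `CC(C)(C)c1ccc(C(=O)NC(=S)N2CCc3c(OCCCCCOc4ccc(Cl)cc4)cccc32)cc1` carries a 4-(tert-butyl)phenyl group there; in this assay compound 2 gives > 50000 nM, also a limit. Because all three values sit at the limit of > 50000 nM in this assay, at which 3 of the 3 values shown sit, the steps among them cannot be read: a step that the two limits leave unreadable from compound 1 to compound 2, a step that the two limits leave unreadable from compound 1 to compound 3 and a step that the two limits leave unreadable from compound 2 to compound 3. Compound 4 `O=C(NC(=S)N1CCc2c(OCCCCCOc3ccc(Cl)cc3)cccc21)C1CCCC1` is the next relative, and the change from compound 3 is cyclopentyl in place of phenethyl on a carbonyl carbon. For the measured compounds named here, no measured step in this assay bears readably on this change: each of the three known values is only a limit, so neither direction nor size of any effect of the carbonyl substituent is known. The step expected here, a step that the limit leaves unreadable from compound 3 to compound 4, is therefore none beyond the scatter. Compound 4 is expected to give about 70000 nM in this assay, with a range from 30000 nM to 200000 nM, most probably reported once more only as a limit.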

Compound 4, half-maximal cytotoxic concentration: > 50000 nM
Compound 4 was reported as a limit; the forecaster's own chance of this, stated with the estimate: 85%; the middle value is on the limit's open side.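

In this assay compound 4 gives > 50000 nM as a limit of the assay and not a number. Its steps to compound 1, compound 2 and compound 3 cannot be read, because all four values share one limit: the limit of > 50000 nM in this assay, at which 4 of the 4 values shown sit. Still open, on these data alone, is whether the group on the carbonyl carbon changes this read-out at all.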